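Aryl replacement notes in a geranylgeranyl transferase inhibitor series

A few compounds are considered here, and "the series" means these few. Any claim that something is new, unique, unknown or untested is made for them only; others in the source may bear on it.

Measured compounds:
compound 1 `Cn1cncc1C(OCc1ccc(C#N)c(-c2ccc3ccccc3c2)n1)c1ccc(C#N)cc1` — 2600 nM
compound 2 `Cn1cncc1C(OCc1ccc(C#N)c(-c2ccc(Cl)c(Cl)c2)n1)c1ccc(C#N)cc1` — 1600 nM

For the measured compounds named here, in an assay on isolated protein (Bos taurus) for inhibition of geranylgeranyl transferase type-1 subunit beta (Homo sapiens) (on this read-out higher numbers stand for weaker inhibition and lower numbers for stronger inhibition), compound 2 gives 1600 nM, the lower of the two numbers so far, but its only neighbour is compound 1, and the step of a 1.6-fold lower number from compound 1 to compound 2 (0.21 log units; within the scatter) is within the scatter, so the two compounds cannot be separated on this read-out.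

Compound 3 `Cn1cncc1C(OCc1ccc(C#N)c(-c2ccc(Cl)cc2)n1)c1ccc(C#N)cc1` differs from compound 2 by hydrogen in place of chloro on an aromatic carbon. Going by the values given here, no measured step touches this chloro group: the single step in hand, from compound 1 to compound 2, concerns the whole aryl group and stayed within the scatter. Nothing in the data therefore points to a shift beyond the scatter for compound 3, and the expected step is a 1.3-fold higher number from compound 2 to compound 3 (0.10 log units; within the scatter), a marginal drift towards a higher number at most. The estimate for compound 3 in this assay is 2000 nM, with a range from 800 nM to 5000 nM.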

Compound 3, half-maximal inhibitory concentration: 3900 nM
Beside the measured number, compound 3's estimate is 2.0-fold (0.29 log units) below it; the range from low to high includes it.
By their numbers in this assay, from the lowest: compounds 2, 1 and 3 (each within the scatter of the next, the first and the last beyond it).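

In this assay, the chloro group lost between the 3,4-dichlorophenyl and 4-chlorophenyl groups has a readable effect: a 2.4-fold higher number from compound 2 to compound 3 (0.39 log units; beyond the scatter) is the only step among these compounds beyond the scatter, if only modestly. The whole-aryl comparison does not show this, since a 1.5-fold higher number from compound 1 to compound 3 (0.18 log units; within the scatter) stays within the scatter, as does the step from naphthalen-2-yl to 3,4-dichlorophenyl, leaving naphthalen-2-yl inseparable from either chlorinated aryl group. No available data bear on what lies behind the step on removing this chloro group.

Open, going by these compounds, is whether a fluoro, a methyl or an amine at this place would give a number like that of compound 2 rather than that of compound 3. Also open, on these data alone, is how an unsubstituted phenyl on the shared core would read against compound 3.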